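Replacing a Sulfonamide Side Group with Hydrogen

A few compounds are considered here, and "the series" means these few. Any claim that something is new, unique, unknown or untested is made for them only; others in the source may bear on it.

A first safety question for any new compound is how readily it harms living cells. Of the compounds shown here, two have so far been tested in an ADME assay on CHO cells (Cricetulus griseus) for cytotoxicity, read by MTT assay (on this read-out higher numbers stand for weaker inhibition and lower numbers for stronger inhibition), for that purpose. Compound 1 (`O=S(=O)(NCC1COC1)c1cccc(-c2ccc3nccc(-c4ccncc4)c3n2)c1`) gives 16000 nM and compound 2 (`O=S(=O)(NCCN1CCCC1)c1cccc(-c2ccc3nccc(-c4ccnc(C(F)(F)F)c4)c3n2)c1`) gives 13000 nM on this measure. These two numbers lie within the usual scatter of each other, so compound 1 cannot be ranked apart from compound 2.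

Compound 3 (`NS(=O)(=O)c1cccc(-c2ccc3nccc(-c4ccncc4)c3n2)c1`) has not yet been measured. It differs from compound 1 in one place, with hydrogen in place of (oxetan-3-yl)methyl on a sulfonamide nitrogen. The core of compound 1 stays the same. Within the data shown here, no measured pair of compounds shows what this change does, so any forecast is cautious. Among the measured compounds shown here, the only guide is that compound 1 at 16000 nM and compound 2 at 13000 nM sit close together. In this assay the estimate is a 1.1-fold lower number from compound 1 to compound 3 (0.03 log units; within the scatter) and so no expected change beyond the scatter in either direction. Compound 3 is therefore expected at 15000 nM with an estimated range from 6000 nM to 40000 nM when the measurement arrives.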

Compound 3, half-maximal inhibitory concentration: 2000 nM
Beside the measured number, compound 3's estimate is 7.5-fold (0.88 log units) above it; measured number outside the range, below it.
By their numbers in this assay, from the lowest: compound 3; then compounds 2 and 1 (each within the scatter of the next).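

In this assay, putting hydrogen in place of (oxetan-3-yl)methyl on the sulfonamide nitrogen gives an 8.0-fold lower number from compound 1 to compound 3 (0.90 log units; beyond the scatter), so a lower number here means that less of the compound is needed to produce the same effect on the cells. Among these compounds, this is the first single-place change, and it shows that what sits on this nitrogen can shift the read-out beyond the usual scatter, which compounds that both carry a side group there could not reveal. The data shown do not explain why removing the side group has this effect.

As far as these compounds go, it remains open whether any group on this nitrogen would keep the number high, or whether the effect depends on the particular group: a single methyl group, a longer carbon chain or a chain ending in a carboxylic acid could each land anywhere relative to the hydrogen and (oxetan-3-yl)methyl ends of this step. From the compounds shown here alone, it is also open whether the same swap would produce a step of similar size on a compound that carries the trifluoromethyl group of compound 2.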